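Swapping the amide substituent in a weak antiproliferative series

A few compounds are considered here, and "the series" means these few. Any claim that something is new, unique, unknown or untested is made for them only; others in the source may bear on it.

Of the compounds shown here, two have been measured in a functional assay on HepG2 cells (Homo sapiens) for antiproliferative activity, read by MTT assay, with a stated time of 48 h; a lower number here means a stronger inhibitor, a higher number a weaker inhibitor. Compound 1 `CCn1c(C(=O)N(CCC#N)CCC#N)ccc1C(CC)(CC)c1ccc(OCCC(O)(CC)CC)c(C)c1` gives 46300 nM and stands as the higher of the two numbers, so it is the weaker inhibitor of the pair. Compound 2 `CCn1c(C(=O)NC(CC(=O)O)C(=O)OC)ccc1C(CC)(CC)c1ccc(OCCC(O)(CC)CC)c(C)c1` gives 10700 nM. For the measured compounds named here, the step between them, a 4.3-fold lower number from compound 1 to compound 2 (0.64 log units; beyond the scatter), replaces one group on the carbonyl carbon with another and is the only step so far that bears on changes at that position.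

Compound 3 `CCn1c(C(=O)N(C)CCO)ccc1C(CC)(CC)c1ccc(OCCC(O)(CC)CC)c(C)c1` has not yet been measured. It differs from compound 1 as follows: a group of 5 heavy atoms (3 carbon, 1 nitrogen, 1 oxygen; no ring) in place of a group of 9 heavy atoms (6 carbon, 3 nitrogen; no ring), on a carbonyl carbon. This again alters the group on the carbonyl carbon, as in the step to compound 2, but the entering group is different in kind, so that step is only a rough guide. A small gain, or none beyond the scatter, is expected, giving a 1.9-fold lower number from compound 1 to compound 3 (0.27 log units; within the scatter). Compound 3 is therefore expected at about 25000 nM, within a range of 8000 nM to 70000 nM.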

Compound 3, half-maximal inhibitory concentration: 510 nM
The estimate for compound 3 lay 49-fold (1.69 log units) above the measured number, and the stated range ends above it.
By their numbers in this assay, from the lowest: compound 3; then compound 2; then compound 1.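

In this assay the group on this carbonyl carbon can matter far more than the first pair suggested: exchanging the two nitrile-bearing chains for (2-hydroxyethyl)(methyl)amino gives a 91-fold lower number from compound 1 to compound 3 (1.96 log units; beyond the scatter) as a large step, not a modest one. The same entering group also outperforms the group of compound 2, with a 21-fold lower number from compound 2 to compound 3 (1.32 log units; beyond the scatter) as the step, yet heavy-atom count alone does not order the three, for compound 2 carries the largest group and still has a lower number than compound 1. Nothing available explains why this group performs so much better.

From the compounds shown here alone, compound 3 carries both a methyl and a 2-hydroxyethyl group on the amide nitrogen, so the share of each in the gain remains open. A dimethylamino group, a 2-hydroxyethylamino group or a longer 3-hydroxypropyl chain at this position would help to separate them.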